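The source may hold more compounds than are shown below. What is called first, only, known or untested is meant among the compounds shown, and "the series" means these compounds.

Three compounds share one core and differ only in the aryl group attached to it. Compound 1 `COc1cc(-c2ccnc3cc(-c4ccc5cc[nH]c5c4)nn23)cc(OC)c1OC` carries a 1H-indol-6-yl group there, and in a functional assay on A549 cells (Homo sapiens) for inhibition, read by CCK-8 assay, with a stated time of 48 h (a higher number here means a weaker inhibitor, a lower number a stronger inhibitor), compound 1 gives 170 nM. Compound 2 `COc1ccc(-c2cc3nccc(-c4cc(OC)c(OC)c(OC)c4)n3n2)cc1F` carries a 3-fluoro-4-methoxyphenyl group, and in this assay compound 2 gives 545 nM. Compound 3 `COc1cc(-c2ccnc3cc(-c4ccccc4)nn23)cc(OC)c1OC` carries a plain phenyl group, and in this assay compound 3 gives 208 nM. Among these three numbers compound 3 holds the second highest place: its gap to compound 1 is small, a 1.2-fold higher number from compound 1 to compound 3 (0.09 log units; within the scatter), while its gap to compound 2 is larger, a 2.6-fold lower number from compound 2 to compound 3 (0.42 log units; beyond the scatter).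

Compound 4 `COc1cc(-c2ccnc3cc(-c4ccc(N(C)C)cc4)nn23)cc(OC)c1OC` differs from compound 3 by dimethylamino in place of hydrogen on an aromatic carbon. Dimethylamino appears nowhere among the measured compounds, so no step tests exactly this change. Among the compounds with values here, the steps that bear on it are those that swapped the same aryl group: a 1.2-fold higher number from compound 1 to compound 3 (0.09 log units; within the scatter) and a 3.2-fold higher number from compound 1 to compound 2 (0.51 log units; beyond the scatter) alongside a 2.6-fold lower number from compound 2 to compound 3 (0.42 log units; beyond the scatter). Changes at this site have moved this assay by a modest amount at most, and sometimes not beyond the scatter. A modest step in either direction, or none beyond the scatter, is therefore expected for compound 4, estimated as a 1.3-fold higher number from compound 3 to compound 4 (0.10 log units; within the scatter). In this assay compound 4 is estimated at 260 nM, with a range from 100 nM to 700 nM.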

Compound 4, half-maximal inhibitory concentration: 1100 nM
Compound 4: middle estimate off by 4.2-fold (0.63 log units), on the low side; the measured number lies above the stated range.
By their numbers in this assay, from the lowest: compounds 1 and 3 (each within the scatter of the next); then compounds 2 and 4 (each within the scatter of the next).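

The dimethylamino group, placed on the phenyl ring of compound 3 para to a large group, gives a 5.3-fold higher number from compound 3 to compound 4 (0.72 log units; beyond the scatter) in this assay, a larger step than any seen among the first three compounds, so this position is more sensitive than those compounds suggested. The step against the indole-bearing compound is similar, a 6.5-fold higher number from compound 1 to compound 4 (0.81 log units; beyond the scatter), while the step to the other compound with a substituted phenyl ring is a 2.0-fold higher number from compound 2 to compound 4 (0.30 log units; within the scatter), which places the 4-(dimethylamino)phenyl and 3-fluoro-4-methoxyphenyl compounds together at the high end of the numbers and compounds 1 and 3 together at the low end. No measurement here accounts for the size of this step.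

From the compounds shown here alone, it remains open whether this rise belongs to dimethylamino in particular or would follow from other groups at the same place, such as a lone methoxy, a plain amino group or a carboxylic acid. A smaller or larger amine, such as methylamino or a piperidine ring, would help show whether the two methyl groups on the nitrogen matter.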